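This account rests on a few compounds, and the source may have more. Where it says the series, first, only, none or still open, it means among the compounds named here.

Notes on the series. Compound 1 `O=C1c2c(ccc(O)c2O)CN1Cc1cccc(Cl)c1` and compound 3 `O=C1c2c(ccc(O)c2O)CN1Cc1cccc(Br)c1` share one core; compound 2 `O=C1c2ccc(O)c(O)c2C(=O)N1Cc1cccc(Cl)c1` and compound 4 `O=C1c2ccc(O)c(O)c2C(=O)N1Cc1cccc(Br)c1` share another. The difference between the two cores is not broken down here.

In an ADME assay on HOS cells (Homo sapiens) for cytotoxicity (a higher number here means a weaker inhibitor, a lower number a stronger inhibitor), compound 1 gives 9020 nM. In this assay compound 3 gives 7240 nM, and compound 2 gives 13300 nM. The three values lie within the scatter of one another, so no order among them is read.

Compound 3 differs from compound 1 by bromo in place of chloro on an aromatic carbon. That change made a 1.2-fold lower number from compound 1 to compound 3 (0.10 log units; within the scatter).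

Compound 4 is not yet measured in this assay. It differs from compound 2 by bromo in place of chloro on an aromatic carbon. The groups that leave and enter and the place of the change are the same as in the change from compound 1 to compound 3, so this is the same change carried onto the other core. Among the measured compounds shown here, whether it behaves the same on the core of compound 2 is not known from the data; the one measured occurrence is the only guide.

For compound 4 the expected step is a 1.2-fold lower number from compound 2 to compound 4 (0.08 log units; within the scatter), of about the size seen in a 1.2-fold lower number from compound 1 to compound 3 (0.10 log units; within the scatter). That expectation rests on the single measured occurrence of the change and on the starting point set by compound 2 at 13300 nM. Since the measured step lies within the scatter, the number expected for compound 4 sits close to that of compound 2. Compound 4 is expected to give 11000 nM in this assay, within a range from 5500 nM to 22000 nM.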

Compound 4, half-maximal inhibitory concentration: 11400 nM
Estimate against measurement, compound 4: 1.0-fold (0.02 log units) below, within the range that was stated.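

In this assay, bromo in place of chloro on an aromatic carbon, read on the core of compound 2, gives a 1.2-fold lower number from compound 2 to compound 4 (0.07 log units; within the scatter), so the swap from 3-chlorophenyl to 3-bromophenyl leaves no readable mark on this core. The two occurrences of the change agree: the same change on two cores in this assay, a 1.2-fold lower number (0.10 log units; within the scatter) from compound 1 to compound 3 and a 1.2-fold lower number (0.07 log units; within the scatter) from compound 2 to compound 4, 1.1-fold (0.03 log units) apart, within the scatter of two such steps

Among the compounds shown here, this shows only that a step too small to read on the core of compound 1 stays too small to read on the core of compound 2; with a single pair on each core, it does not establish a rule for other cores, and it does not test whether a step large enough to read would carry across in the same way.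

The compounds shown hold only chloro and bromo on an aromatic carbon of the benzyl-free end of the series, the 3-chlorophenyl and 3-bromophenyl groups, so whether a nitrile, a methoxy group or a carboxylic acid in that place would give a step beyond the scatter stays open. Also open, on these data alone, is how the same change reads outside this assay, and whether it would hold on a core carrying something other than the two hydroxyl groups, such as an amine.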